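A few compounds are considered here, and "the series" means these few. Any claim that something is new, unique, unknown or untested is made for them only; others in the source may bear on it.

Compound 1 `CN(CCC1CCNCC1)C(=O)c1ccc2c(c1)CC(CC(=O)O)C(=O)N(CCC(C)(C)C)C2` carries a 3,3-dimethylbutyl group on the ring amide nitrogen of the shared core, and in a functional assay (plasma) for inhibition, with Homo sapiens as the target (on this read-out higher numbers stand for weaker inhibition and lower numbers for stronger inhibition), compound 1 gives 27 nM. Among the three measured compounds this is the second highest number: compound 2 `CN(CCC1CCNCC1)C(=O)c1ccc2c(c1)CC(CC(=O)O)C(=O)N(Cc1ccccc1)C2`, which gives 36 nM in this assay, sits nearest, and the step of a 1.3-fold higher number from compound 1 to compound 2 (0.12 log units; within the scatter) lies within the scatter; compound 3 `CN(CCC1CCNCC1)C(=O)c1ccc2c(c1)CC(CC(=O)O)C(=O)N(CCCCCc1ccccc1)C2`, which gives 8 nM, sits furthest, with the step of a 3.4-fold lower number from compound 1 to compound 3 (0.53 log units; beyond the scatter). The step of a 4.5-fold lower number from compound 2 to compound 3 (0.65 log units; beyond the scatter) points the same way.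

Compound 4 `CN(CCC1CCNCC1)C(=O)c1ccc2c(c1)CC(CC(=O)O)C(=O)NC2` differs from compound 1 in one place: hydrogen in place of 3,3-dimethylbutyl on an amide-type nitrogen in a ring. Going by the values given here, all three measured steps exchange one group for another on this same nitrogen, and none of them removes the substituent altogether, so no measured step matches the change directly. What they do show is that a long chain ending in a phenyl ring, as in compound 3, gives the lowest number, while the shorter groups of compound 1 and compound 2 give higher numbers that are within the scatter of one another. Taking the substituent away entirely is therefore expected to move the number in the other direction, by a modest amount, as a 3.0-fold higher number from compound 1 to compound 4 (0.47 log units; beyond the scatter). In this assay compound 4 is estimated at 80 nM, with a range from 25 nM to 300 nM.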

Compound 4, half-maximal inhibitory concentration: 71 nM
Beside the measured number, compound 4's estimate is 1.1-fold (0.05 log units) above it, within the range that was stated.
By their numbers in this assay, from the lowest: compound 3; then compounds 1, 2 and 4 (each within the scatter of the next, the first and the last beyond it).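

Going by these compounds alone, with compound 4 the amide-type nitrogen in the ring is seen for the first time carrying only hydrogen, and in this assay the shared core keeps a measurable inhibition without any chain there, while the loss of 3,3-dimethylbutyl is a step beyond the scatter (a 2.6-fold higher number from compound 1 to compound 4 (0.42 log units; beyond the scatter)). The loss of 5-phenylpentyl gives the largest of the new steps (an 8.9-fold higher number from compound 3 to compound 4 (0.95 log units; beyond the scatter)), whereas benzyl cannot be told apart from hydrogen at this position (a 2.0-fold higher number from compound 2 to compound 4 (0.29 log units; within the scatter)), so the substituents on this nitrogen do not all count alike, with benzyl as the one that goes against a general gain over hydrogen. Nothing available here accounts for these differences.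

The compounds shown leave open how chains of intermediate length ending in a phenyl ring, such as 2-phenylethyl or 3-phenylpropyl, would read on this nitrogen, as the only phenyl-bearing groups here are benzyl and 5-phenylpentyl. They also leave open whether a longer chain than 5-phenylpentyl, or a chain ending in an amine or a carboxylic acid, would go with compound 3 or with compound 4.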